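Methoxy and nitro substituents on a shared core

The source may report more compounds than this note shows. Statements on the series, on what has been measured and on what is new or still open speak of the compounds shown alone.

Measured in an assay for inhibition of Thromboxane-A synthase (Homo sapiens), using microsomes; a lower number here means a stronger inhibitor, a higher number a weaker inhibitor:
compound 1 `CC(C)(Oc1ccccc1)C1OCC(C/C=C\CCC(=O)O)C(c2cccnc2)O1`: 52 nM
compound 2 `COc1ccc(OC(C)(C)C2OCC(C/C=C\CCC(=O)O)C(c3cccnc3)O2)cc1`: 41 nM
compound 3 `CC(C)(Oc1ccccc1[N+](=O)[O-])C1OCC(C/C=C\CCC(=O)O)C(c2cccnc2)O1`: only a limit, < 10 nM

Compound 1 to compound 2 is methoxy in place of hydrogen on an aromatic carbon; the step is a 1.3-fold lower number from compound 1 to compound 2 (0.10 log units; within the scatter). Compound 1 to compound 3 is nitro in place of hydrogen on an aromatic carbon; the step is an at least 5.2-fold lower number from compound 1 to compound 3 (0.71 log units; beyond the scatter), bounded by the limit of < 10 nM in this assay, at which 1 of the 3 values shown sits. Between compound 2 and compound 3 the step is an at least 4.1-fold lower number from compound 2 to compound 3 (0.61 log units; beyond the scatter).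

Compound 4 `COc1ccc(OC(C)(C)C2OCC(C/C=C\CCC(=O)O)C(c3cccnc3)O2)c([N+](=O)[O-])c1` is not yet measured. Compound 3 to compound 4 is methoxy in place of hydrogen on an aromatic carbon, the same kind of change as from compound 1 to compound 2, but here the place is also meta to a nitro group. The two cores differ by nitro in place of hydrogen on an aromatic carbon.

From compound 3 to compound 4 a step that the limit leaves unreadable from compound 3 to compound 4 is expected, resting on the step of a 1.3-fold lower number from compound 1 to compound 2 (0.10 log units; within the scatter). Compound 4 is therefore estimated at 7 nM, between 3 nM and 20 nM.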

Compound 4, half-maximal inhibitory concentration: 37 nM
Compound 4: the middle estimate sits 5.3-fold (0.72 log units) below what was measured; measured number outside the range, above it.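

Methoxy in place of hydrogen gives an at least 3.7-fold higher number from compound 3 to compound 4 (0.56 log units; beyond the scatter) in this assay, so this change does not carry over unchanged from the core of compound 1 to the core of compound 3: the same change on two cores in this assay, a 1.3-fold lower number (0.10 log units; within the scatter) from compound 1 to compound 2 and an at least 3.7-fold higher number (0.56 log units; beyond the scatter) from compound 3 to compound 4, at least 4.6-fold (0.67 log units) apart, beyond the scatter of two such steps
Nitro in place of hydrogen also depends on the core, with a 1.1-fold lower number from compound 2 to compound 4 (0.04 log units; within the scatter) and, for both changes together, a 1.4-fold lower number from compound 1 to compound 4 (0.15 log units; within the scatter): the same change on two cores in this assay, an at least 5.2-fold lower number (0.71 log units; beyond the scatter) from compound 1 to compound 3 and a 1.1-fold lower number (0.04 log units; within the scatter) from compound 2 to compound 4, at least 4.6-fold (0.67 log units) apart, beyond the scatter of two such steps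
Compound 3 stands at a limit of the assay, so these gaps have only a lower bound, and the data do not show why the steps differ: the limit of < 10 nM in this assay, at which 1 of the 4 values shown sits.

Still open, as far as these compounds go, is whether an amine or a nitrile in place of the nitro group would behave as nitro does on these cores. Also open, from the compounds shown here alone, is whether ethoxy in place of methoxy would give the same steps.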